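The source may hold more compounds than are shown below. What is called first, only, known or untested is meant among the compounds shown, and "the series" means these compounds.

For the measured compounds named here, in an assay on isolated protein for inhibition of serine/threonine-protein kinase 10 (Homo sapiens), read by thermal shift assay, tested at 10 uM (a higher number here means that the compound stabilises the target more against heat, a lower number that the compound stabilises the target less), compound 1 `Cc1ccccc1NC(=O)Nc1cc(C(C)(C)C)nn1-c1ccccc1` gives 8.6 degrees C, while compound 3 `CC(C)(C)c1cc(NC(=O)Nc2ccccc2)n(-c2ccccc2)n1` gives 7.2 degrees C. The single step between measured neighbours, a number 1.4 degrees C lower from compound 1 to compound 3 (beyond the scatter), shows how a small edit on the urea-side ring moves this read-out. Compound 2 `CC(C)(C)c1cc(NC(=O)Nc2cc(C(F)(F)F)cc(C(F)(F)F)c2)n(-c2ccccc2)n1` stands lowest of the three in this assay with -0.5 degrees C; its nearest neighbour is compound 3 and its furthest is compound 1, and both gaps lie beyond the scatter.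

Compound 4 `CC(C)(C)c1cc(NC(=O)Nc2cc(C(F)(F)F)cc(C(F)(F)F)c2)n(-c2ccc(F)cc2)n1` differs from compound 2 by fluoro in place of hydrogen on an aromatic carbon, that is, phenyl to 4-fluorophenyl on the ring attached to the core nitrogen. Going by the values given here, no measured step touches this ring, so nothing here shows what a single fluorine there does; the only step on record, the modest one from compound 1 to compound 3, concerns a different ring. On that basis the expected step in this assay, a number 0.50 degrees C higher from compound 2 to compound 4 (within the scatter), is none beyond the scatter. Compound 4 is therefore estimated to give 0 degrees C, within a range from -1.5 degrees C to 2 degrees C.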

Compound 4, shift of the target's melting temperature: -0.6 degrees C
Beside the measured number, compound 4's estimate is 0.60 degrees C above it; low and high end bracket the measured number.
By their numbers in this assay, from the lowest: compounds 4 and 2 (each within the scatter of the next); then compound 3; then compound 1.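

For the compounds shown here, this is the first measured step on the ring that carries the change, and in this assay the swap of phenyl to 4-fluorophenyl reads as a number 0.10 degrees C lower from compound 2 to compound 4 (within the scatter), so fluoro in place of hydrogen on this aromatic carbon, para to a large group, leaves no readable mark. That finding applies only to compounds whose urea-side ring carries two trifluoromethyl groups, and the read-out for this pair already lies close to zero. No measurement on hand offers an explanation for this result.

Going by these compounds, whether chloro, methoxy or an amine on the same carbon would shift the number remains open. Also open, on these data alone, is whether fluoro would behave the same way on compound 3, which gives 7.2 degrees C and has a plain phenyl on its urea side.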